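Swapping the triazole substituent: how compound 3 may fare

The source may report more compounds than this note shows. Statements on the series, on what has been measured and on what is new or still open speak of the compounds shown alone.

Measured so far:
- compound 1 `CC(C)=CCC1=C(OCc2cn(-c3ccnc4cc(Cl)ccc34)nn2)C(=O)c2ccccc2C1=O`: 1940000 nM
- compound 2 `CC(C)=CCC1=C(OCc2cn(-c3cccnc3)nn2)C(=O)c2ccccc2C1=O`: 1030000 nM

In an ADME assay on HepG2 cells (Homo sapiens) for cytotoxicity, read by MTT assay, with a stated time of 24 h (on this read-out higher numbers stand for lower toxicity in this test and lower numbers for higher toxicity in this test), compound 1 gives 1940000 nM, the highest of the two numbers. Going by the values given here, compound 2 comes nearest, and the only measured step, a 1.9-fold lower number from compound 1 to compound 2 (0.27 log units; within the scatter), stays within the scatter, so the two values cannot be told apart.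

Compound 3 `CC(C)=CCC1=C(OCc2cn(-c3ccc([N+](=O)[O-])cc3)nn2)C(=O)c2ccccc2C1=O` differs from compound 1 in one place: 4-nitrophenyl in place of 7-chloroquinolin-4-yl on an aromatic nitrogen. Among the compounds with values here, the one measured step bears on it only loosely, as it also replaces the same group on the same aromatic nitrogen, and it showed no change beyond the scatter. On that basis no step beyond the scatter is expected here either; the estimated shift is a 1.3-fold lower number from compound 1 to compound 3 (0.11 log units; within the scatter). Compound 3 is therefore expected to give about 1500000 nM in this assay, most likely between 500000 nM and 4500000 nM.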

Compound 3, half-maximal cytotoxic concentration: 540000 nM
Estimate against measurement, compound 3: 2.8-fold (0.44 log units) above, and the stated range covers the measured number.
By their numbers in this assay, from the lowest: compounds 3, 2 and 1 (each within the scatter of the next, the first and the last beyond it).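

The group on the aromatic nitrogen of the five-membered ring can move the number in this assay beyond the scatter: 4-nitrophenyl in place of 7-chloroquinolin-4-yl gives a 3.6-fold lower number from compound 1 to compound 3 (0.56 log units; beyond the scatter), a modest step towards higher toxicity in this test. Against pyridin-3-yl, the same 4-nitrophenyl group gives a 1.9-fold lower number from compound 2 to compound 3 (0.28 log units; within the scatter), so only compound 1 and compound 3, the two ends of the series, can be told apart. Nothing available accounts for this difference.

As far as these compounds go, whether the nitro group or the phenyl ring carrying it matters more stays open, and a plain phenyl or an aminophenyl group at this place would help separate the two. From the compounds shown here alone, all three groups here are aromatic, so the effect of a saturated alkyl chain on this nitrogen also remains unknown.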